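Para-substituent swap on the benzoyl arm of compound 2

The source may hold more compounds than are shown below. What is called first, only, known or untested is meant among the compounds shown, and "the series" means these compounds.

Measured so far:
- compound 1, `O=C(Oc1ccc(-c2cncn2C2CCN(C(=O)c3ccc(Cl)c(C(F)(F)F)c3)CC2)cc1)c1cccs1`, > 10000 nM
- compound 2, `O=C(c1ccc([N+](=O)[O-])cc1)N1CCC(n2cncc2-c2ccc(OS(=O)(=O)c3cccc4cnccc34)cc2)CC1`, 1.49 nM

Compound 1 gives only a limit in an assay on HEK293 cells for antagonist activity at P2X purinoceptor 7 (Homo sapiens), read by fluorescence, with a stated time of 2 h (a lower number here means a stronger inhibitor, a higher number a weaker inhibitor), so it yields no number to compare; the limit of > 10000 nM in this assay, at which 1 of the 2 values shown sits, marks that limit. Among the compounds with values here, compound 2 is therefore the only compound with a measured half-maximal inhibitory concentration, and in this assay compound 2 gives 1.49 nM. Within the data shown here, no step between two measured compounds exists in the set, so the series supplies no calibrated change to lean on.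

Compound 3, `CC(C)(O)c1ccc(C(=O)N2CCC(n3cncc3-c3ccc(OS(=O)(=O)c4cccc5cnccc45)cc3)CC2)cc1`, differs from compound 2 in one place: 1-hydroxy-1-methylethyl in place of nitro on an aromatic carbon, para to a large group. Among the measured compounds shown here, with no measured step available, the expectation for compound 3 rests on compound 2 and the single change alone; a small loss, close to the usual scatter, is expected rather than a large one, as compound 2 at 1.49 nM already sits very low. Compound 3 is estimated at 4 nM, with a range of 1 nM to 20 nM. The step from compound 2 to compound 3 is thus expected to be a 2.7-fold higher number from compound 2 to compound 3 (0.43 log units; beyond the scatter).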

Compound 3, half-maximal inhibitory concentration: 109 nM
Estimate against measurement, compound 3: 27-fold (1.44 log units) below; measured number above the stated range.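

Within the data shown here, the position on an aromatic carbon, para to a large group, is not indifferent to what it carries in this assay: 1-hydroxy-1-methylethyl in place of nitro gives a 73-fold higher number from compound 2 to compound 3 (1.86 log units; beyond the scatter) and provides the first calibrated step, a large one. The exchange alters several counted features together, as nitro brings 0 hydrogen-bond donors and 2 hydrogen-bond acceptors on 3 heavy atoms, whereas 1-hydroxy-1-methylethyl brings 1 hydrogen-bond donor and 1 hydrogen-bond acceptor on 4 heavy atoms, so this single step cannot assign the loss to any one of them. Nothing among the measurements shown bears on why this step is so large.

Going by these compounds, it remains open whether the hydroxyl or the branched carbon framework of 1-hydroxy-1-methylethyl goes with the higher number, and a tert-butyl group at the same place would separate the two. On these data alone, it also remains open whether nitro is unusually favourable here or merely one of several tolerated groups, a question that a nitrile, an amine or a carboxylic acid at this position would help to settle.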